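The source may report more compounds than this note shows. Statements on the series, on what has been measured and on what is new or still open speak of the compounds shown alone.

Series notes. Compound 1 `Cn1nc(C(F)(F)F)cc1C(=O)Nc1ccc(S(=O)(=O)n2ccc3ccccc32)cc1` gives 13000 nM in an ADME assay on Vero cells (Chlorocebus sabaeus) for cytotoxicity, read by MTT assay; on this read-out lower numbers stand for higher toxicity in this test and higher numbers for lower toxicity in this test. Compound 2 `Cn1nc(C(F)(F)F)cc1C(=O)Nc1ccc(S(=O)(=O)N2CCCCC2)cc1` returns only a limit of this assay, > 300000 nM. Compound 3 `Cn1nc(C(F)(F)F)cc1C(=O)Nc1ccc(S(=O)(=O)N2CCCCC2C(=O)O)cc1` likewise returns only a limit, > 300000 nM. Both an at least 23-fold higher number from compound 1 to compound 2 (1.36 log units; beyond the scatter) and an at least 23-fold higher number from compound 1 to compound 3 (1.36 log units; beyond the scatter) are large, whereas a step that the two limits leave unreadable from compound 2 to compound 3; two of the three values rest at the limit of > 300000 nM in this assay, at which 2 of the 3 values shown sit. Compound 4 `Cn1nc(C(F)(F)F)cc1C(=O)Nc1ccc(S(=O)(=O)N2CCNCC2)cc1` differs from compound 3 by piperazin-1-yl in place of 2-carboxypiperidin-1-yl on a sulfonyl sulfur. Going by the values given here, no measured step covers piperazin-1-yl; the nearest comparators are compound 2 carrying piperidin-1-yl and compound 3 carrying 2-carboxypiperidin-1-yl on the sulfonyl sulfur, neither of which yields a number. Compound 4 is therefore expected near 300000 nM, between 150000 nM and 1000000 nM, most probably again as a limit. The step of a number no higher from compound 3 to compound 4 (the limit leaves the size open) is expected to stay within the scatter.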

Compound 4, half-maximal cytotoxic concentration: 126000 nM
For compound 4 the middle estimate is 2.4-fold (0.38 log units) above the measured one, outside the stated range (below it).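

On the sulfonyl sulfur, a saturated ring does not by itself keep the reading at the limit in this assay: piperazin-1-yl brings an at least 2.3-fold lower number from compound 2 to compound 4 (0.37 log units; beyond the scatter) and an at least 2.3-fold lower number from compound 3 to compound 4 (0.37 log units; beyond the scatter). Against 1H-indol-1-yl, the change now has a full size, a 9.7-fold higher number from compound 1 to compound 4 (0.99 log units; beyond the scatter). The step between compound 2 and compound 3 remains unreadable because both values are limits: the limit of > 300000 nM in this assay, at which 2 of the 4 values shown sit.

As far as these compounds go, how far compound 2 and compound 3 truly lie from compound 4 stays open. Also open, from the compounds shown here alone, is whether the lower number follows the second ring nitrogen of piperazin-1-yl, which morpholin-4-yl or 4-methylpiperazin-1-yl on the sulfonyl sulfur could test.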